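A few compounds are considered here, and "the series" means these few. Any claim that something is new, unique, unknown or untested is made for them only; others in the source may bear on it.

Compound 1 `Cc1cc(C)cc(NC(=O)NCCNS(=O)(=O)c2ccc(-c3ccccc3Oc3ccc([N+](=O)[O-])c([N+](=O)[O-])c3)s2)c1` gives 3600 nM
Compound 2 `COc1ccc(Oc2ccc([N+](=O)[O-])cc2-c2ccsc2S(=O)(=O)N2CCN(C(=S)Nc3ccc(Cl)cc3)CC2)cc1OC` gives > 50000 nM
Compound 3 `COc1ccc(NC(=O)NCCNS(=O)(=O)c2sccc2-c2ccc(C)cc2Oc2ccc(O)c(O)c2)cc1` gives 8200 nM

All three compounds were tested in a functional assay on RS4-11 cells (Homo sapiens) for inhibition, read by CCK-8 assay, with a stated time of 48 h (on this read-out lower numbers stand for stronger inhibition and higher numbers for weaker inhibition), and there compound 1 stands at 3600 nM as the lowest of the two true numbers. Compound 3 sits higher at 8200 nM and that gap lies beyond the scatter. Compound 2 reads > 50000 nM and this is a limit of the assay, not a number.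

Compound 4 `O=C(NCCNS(=O)(=O)c1ccc(-c2ccccc2Oc2ccc([N+](=O)[O-])c([N+](=O)[O-])c2)s1)Nc1cc(Cl)cc(Cl)c1` has not yet been measured in this assay and differs from compound 1 in one place: 3,5-dichlorophenyl in place of 3,5-dimethylphenyl on an amide-type nitrogen with 3,5-dichlorophenyl in place of 3,5-dimethylphenyl on an amide-type nitrogen. Among the compounds with values here, no two measured compounds differ in one place only, and the effect of this exchange has not been measured directly. The entering and leaving groups match in their counts of heavy atoms and hydrogen-bond donors and acceptors, and no step beyond the scatter is expected in this assay in either direction. That expectation starts from compound 1 at 3600 nM and stays close to that number. The expected step is a 1.2-fold lower number from compound 1 to compound 4 (0.08 log units; within the scatter) on this estimate. For compound 4 the estimated value is 3000 nM with an expected range from 1000 nM to 9000 nM in this read-out.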

Compound 4, half-maximal inhibitory concentration: 2100 nM
The estimate for compound 4 lay 1.4-fold (0.15 log units) above the measured number; measured number inside the range.
By their numbers in this assay, from the lowest: compounds 4 and 1 (each within the scatter of the next); then compound 3. At a limit, above all of these: compound 2.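

Within the data shown here, the exchange reads as a 1.7-fold lower number from compound 1 to compound 4 (0.23 log units; within the scatter) in this assay and is the first step between two compounds that differ in one place only. It shows that on the amide-type nitrogen, with the rest of compound 1 unchanged, 3,5-dichlorophenyl can stand in place of 3,5-dimethylphenyl without a change that can be told from the usual scatter of this read-out, with the heavy-atom, donor and acceptor counts of the two groups matching. Nothing measured here bears on why the step has this size.

The compounds shown leave open whether other groups on this nitrogen, such as an unsubstituted phenyl, a cyclohexyl group or a phenyl ring carrying an amine or a carboxylic acid, would stay within the scatter of compound 1 or move beyond it. Among these compounds, they also leave open whether the same exchange would read the same way on another core, such as that of compound 3, where the step has no measured pair.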